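Ring nitrogen substitution on the terminal piperazine

The source may hold more compounds than are shown below. What is called first, only, known or untested is meant among the compounds shown, and "the series" means these compounds.

Compound 1 `CCN(CC)c1ccc2cc(C(=O)c3ccc(N4CCN(C(=O)CN5CCNCC5)CC4)cc3)oc2c1` keeps a hydrogen on the amine nitrogen of the outer six-membered ring. In a functional assay on A549 cells (Homo sapiens) for cytotoxicity, read by MTT assay, with a stated time of 48 h (a lower number here means a stronger inhibitor, a higher number a weaker inhibitor), compound 1 gives 320 nM, the lowest of the numbers shown here. Compound 2 `CCN(CC)c1ccc2cc(C(=O)c3ccc(N4CCN(C(=O)CN5CCN(S(=O)(=O)c6ccc(F)cc6)CC5)CC4)cc3)oc2c1` gives 33200 nM in this assay, a step of a 100-fold higher number from compound 1 to compound 2 (2.02 log units; beyond the scatter). Compound 3 `C#CCN1CCN(CC(=O)N2CCN(c3ccc(C(=O)c4cc5ccc(N(CC)CC)cc5o4)cc3)CC2)CC1` reaches only a limit in this assay, recorded as > 40000 nM. The step to it is an at least 120-fold higher number from compound 1 to compound 3 (2.09 log units; beyond the scatter), and between the two substituted compounds it is an at least 1.2-fold higher number from compound 2 to compound 3 (0.08 log units; that floor lies within the scatter).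

Compound 4 `CCN(CC)c1ccc2cc(C(=O)c3ccc(N4CCN(C(=O)CN5CCN(CC(C)=O)CC5)CC4)cc3)oc2c1` differs from compound 1 by 2-oxopropyl in place of hydrogen on an amine nitrogen in a ring. Both measured substitutions on that ring nitrogen, the (4-fluorophenyl)sulfonyl and the propargyl, gave large upward steps, one of them recorded only as a limit (the limit of > 40000 nM in this assay, at which 1 of the 3 values shown sits). For the measured compounds named here, for the 2-oxopropyl no measured step exists, but the two steps bearing on this position point the same way, so a large upward step in this assay is expected for compound 4, estimated at a 47-fold higher number from compound 1 to compound 4 (1.67 log units; beyond the scatter). Compound 4 is therefore estimated at 15000 nM, with a range from 2500 nM to 40000 nM.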

Compound 4, half-maximal inhibitory concentration: 8920 nM
The estimate for compound 4 lay 1.7-fold (0.23 log units) above the measured number; low and high end bracket the measured number.
By their numbers in this assay, from the lowest: compound 1; then compound 4; then compound 2. At a limit, above all of these: compound 3.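

All substituents shown on this ring nitrogen now sit far above the hydrogen of compound 1 in this assay (a 28-fold higher number from compound 1 to compound 4 (1.45 log units; beyond the scatter)), and the 2-oxopropyl extends that pattern with no compound shown against it. The substituents also separate from one another (a 3.7-fold lower number from compound 2 to compound 4 (0.57 log units; beyond the scatter)), so the size of the step depends on the group entering and not only on the hydrogen leaving. Compound 3 is recorded only at a limit, so the comparison with it gives a floor (an at least 4.4-fold lower number from compound 3 to compound 4 (0.65 log units; beyond the scatter)): (the limit of > 40000 nM in this assay, at which 1 of the 4 values shown sits).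

As far as these compounds go, whether any group on this nitrogen, such as a methyl or a 2-hydroxyethyl, stays close to compound 1 remains open. Also open, from the compounds shown here alone, is what the ketone carbonyl contributes, a question that a plain propyl chain on the same nitrogen would address.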